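This account rests on a few compounds, and the source may have more. Where it says the series, first, only, none or still open, it means among the compounds named here.

Within the data shown here, compound 2 `COc1ccc(NC(=O)c2cc(Oc3ccc(/C=C/c4ccncc4)cc3)ccn2)cc1` is the weaker of the two measured members: in a functional assay on A549 cells (Homo sapiens) for antiproliferative activity, read by CCK-8 assay, with a stated time of 48 h (a higher number here means a weaker inhibitor, a lower number a stronger inhibitor), compound 2 gives 25600 nM, the higher of two numbers, with compound 1 `COc1ccc(NC(=O)c2cc(Oc3ccc(/C=C/c4ccccn4)cc3)ccn2)cc1` nearest at 20000 nM, though the step of a 1.3-fold higher number from compound 1 to compound 2 (0.11 log units; within the scatter) lies within the scatter. Compound 3 `COc1ccc(CNC(=O)c2cc(Oc3ccc(/C=C/c4ccncc4)cc3)ccn2)cc1` carries the change (4-methoxybenzyl in place of 4-methoxyphenyl on an amide-type nitrogen). Among the measured compounds shown here, the one measured step concerns the pyridyl end of the chain, not the amide-type nitrogen, so no measured step bears on this change. With nothing to indicate a shift, the step of a 1.1-fold lower number from compound 2 to compound 3 (0.03 log units; within the scatter) is expected to stay within the scatter. Compound 3 is therefore estimated at 24000 nM, with a range from 8000 nM to 70000 nM.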

Compound 3, half-maximal inhibitory concentration: 19300 nM
For compound 3 the middle estimate is 1.2-fold (0.09 log units) above the measured one; the range from low to high includes it.
By their numbers in this assay, from the lowest: compounds 3, 1 and 2 (each within the scatter of the next).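

Among these compounds, on the amide-type nitrogen, the first measured step in this assay is a 1.3-fold lower number from compound 2 to compound 3 (0.12 log units; within the scatter), so 4-methoxybenzyl in place of 4-methoxyphenyl leaves the number within the scatter. This holds here for the pyridin-4-yl member only, and it shows that this position tolerates the change without a measurable shift in this read-out. No evidence on a cause accompanies this result.

From the compounds shown here alone, it remains open whether the same change behaves alike with the pyridin-2-yl end of compound 1. Also open, going by these compounds, is whether a different group on this nitrogen, such as an amine or a carboxylic acid on a longer chain, would move the number beyond the scatter.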